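The compounds below may be only part of what the source reports. "The series", "measured", "known", "first", "only" and "open" are said of these compounds alone.

Measured in a functional assay on RS4-11 cells (Homo sapiens) for inhibition, read by CCK-8 assay, with a stated time of 48 h; a higher number here means a weaker inhibitor, a lower number a stronger inhibitor:
- compound 1 `O=C(NCCNS(=O)(=O)c1ccc(-c2ccccc2Oc2ccc([N+](=O)[O-])c([N+](=O)[O-])c2)s1)Nc1cc(Cl)cc(Cl)c1`: 2100 nM
- compound 2 `O=C(NCCNS(=O)(=O)c1ccc(-c2ccccc2OCc2ccccc2)s1)Nc1cc(Cl)cc(Cl)c1`: > 20000 nM (a limit of the assay)
- compound 3 `O=C(NCCNS(=O)(=O)c1ccc(-c2ccccc2O[C@H]2CC[C@H](O)CC2)s1)Nc1cc(Cl)cc(Cl)c1`: 14100 nM

Compound 1 holds the lowest number here, and compound 3 is its nearest measured neighbour. Compound 4 `O=C(NCCNS(=O)(=O)c1ccc(-c2ccccc2Oc2ccc([N+](=O)[O-])c([N+](=O)[O-])c2)s1)Nc1ccc(Cl)cc1` keeps the rest of compound 1 and has 4-chlorophenyl in place of 3,5-dichlorophenyl on an amide-type nitrogen. Going by the values given here, no measured step touches that nitrogen. The two steps away from compound 1, an at least 9.5-fold higher number from compound 1 to compound 2 (0.97 log units; beyond the scatter) and a 6.7-fold higher number from compound 1 to compound 3 (0.83 log units; beyond the scatter), change the group on the oxygen instead, so they offer only a rough guide to size. A smaller rise in the number is therefore expected in this assay. The expected change is a 1.9-fold higher number from compound 1 to compound 4 (0.28 log units; within the scatter). For compound 4 the estimated value is 4000 nM, with an expected range of 1500 nM to 12000 nM.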

Compound 4, half-maximal inhibitory concentration: 6700 nM
For compound 4 the middle estimate is 1.7-fold (0.22 log units) below the measured one; low and high end bracket the measured number.
By their numbers in this assay, from the lowest: compound 1; then compound 4; then compound 3. At a limit, above all of these: compound 2.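

The group on the amide-type nitrogen matters in this assay: 4-chlorophenyl in place of 3,5-dichlorophenyl gives a 3.2-fold higher number from compound 1 to compound 4 (0.50 log units; beyond the scatter). This single change removes one chlorine and also alters the ring's substitution pattern, so the step cannot separate the two. Nothing given here explains the rise in the number.

Plain phenyl or 3-chlorophenyl at this nitrogen would help show whether chlorine number or placement counts. As far as these compounds go, it also remains open whether a saturated ring such as cyclohexyl, or a longer chain such as benzyl, could replace the aromatic ring.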